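Adding a Fluorine to the Central Ring of Compound 2

The compounds below may be only part of what the source reports. "The series", "measured", "known", "first", "only" and "open" are said of these compounds alone.

Compound 1, `O=C(Nc1ccc(Oc2ccnc3[nH]ccc23)cc1)c1cc(-c2ccc(C(F)(F)F)cc2)ncn1`: 6240 nM in a functional assay on MCF7 cells (Homo sapiens) for cytotoxicity, read by MTT assay, with a stated time of 72 h; a lower number here means a stronger inhibitor, a higher number a weaker inhibitor
Compound 2, `O=C(Nc1ccc(Oc2ccnc3[nH]ccc23)cc1)c1cc(-c2ccccc2)ncn1`: 20 nM
Compound 3, `O=C(Nc1ccc(Oc2ccnc3[nH]ccc23)cc1)c1cc(-c2ccc(Br)cc2)ncn1`: 3840 nM

Compound 2 has the lowest number of the three in this assay. Its nearest neighbour is compound 3, reached by the step of a 190-fold higher number from compound 2 to compound 3 (2.28 log units; beyond the scatter), and the step of a 310-fold lower number from compound 1 to compound 2 (2.49 log units; beyond the scatter) separates it from compound 1. The step of a 1.6-fold lower number from compound 1 to compound 3 (0.21 log units; within the scatter) shows that the two substituted compounds sit close together.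

Compound 4, `O=C(Nc1ccc(Oc2ccnc3[nH]ccc23)c(F)c1)c1cc(-c2ccccc2)ncn1`, keeps the whole of compound 2 and changes one point: fluoro in place of hydrogen on an aromatic carbon. The place is on the six-membered aromatic ring of carbon only that carries the amide nitrogen and the ether oxygen, ortho to a large group and meta to a large group.

All three measured steps concern the other aromatic ring, the one bearing trifluoromethyl, bromo or hydrogen; none of them changes the ring touched here. They show that this core can react strongly to a single change on an aromatic carbon, but they say nothing direct about a fluoro at this place. The expectation for the step from compound 2 to compound 4 is therefore a small one, a 1.5-fold higher number from compound 2 to compound 4 (0.18 log units; within the scatter), with no direction beyond the scatter assured. Compound 4 is estimated at 30 nM, in the range 8 nM to 120 nM.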

Compound 4, half-maximal inhibitory concentration: 4640 nM
For compound 4 the middle estimate is 150-fold (2.19 log units) below the measured one; the measured number lies above the stated range.
By their numbers in this assay, from the lowest: compound 2; then compounds 3, 4 and 1 (each within the scatter of the next).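

In this assay, the fluoro turns out to matter a great deal: this one replacement of hydrogen, adding a single heavy atom, gives a 230-fold higher number from compound 2 to compound 4 (2.37 log units; beyond the scatter). Until now, large steps were known only from the other aromatic ring, as in a 190-fold higher number from compound 2 to compound 3 (2.28 log units; beyond the scatter), so this result shows that the sensitivity of compound 2 also extends to the six-membered aromatic ring of carbon only that carries the amide nitrogen and the ether oxygen. Nothing available here explains why so small a change has so large an effect.

The compounds shown leave open whether this effect belongs to fluoro itself or to any replacement of hydrogen at this place, a question that a chloro, a methyl or a methoxy group at the same carbon could help to answer. They also leave open whether an amine or a carboxylic acid at this place would give a number close to that of compound 2, and whether a fluoro on another carbon of this ring would give a step of similar size.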